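Bromoacrylamide series: aryl variation on the fused thiazole core

The compounds below may be only part of what the source reports. "The series", "measured", "known", "first", "only" and "open" are said of these compounds alone.

Compound 2 `C=C(Br)C(=O)Nc1cccc(-c2cn3nc(CCc4ccccc4)sc3n2)c1` is measured in a functional assay on HeLa cells (Homo sapiens) for inhibition, read by cell counting, with a stated time of 4 days (a lower number here means a stronger inhibitor, a higher number a weaker inhibitor), where compound 2 gives 3300 nM. Compound 1 `C=C(Br)C(=O)Nc1cccc(-c2cn3c(-c4ccccc4)csc3n2)c1`, which carries phenyl in the corresponding position, gives 3400 nM in this assay, a value within the scatter of compound 2. Compound 3 `Nc1cccc(-c2cn3nc(-c4ccc(F)cc4)sc3n2)c1`, which lacks the acrylamide, reaches only the assay limit of >= 250000 nM in this assay; this is a limit, not a number (the limit of >= 250000 nM in this assay, at which 1 of the 3 values shown sits).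

Compound 4 `C=C(Br)C(=O)Nc1cccc(-c2cn3nc(-c4ccc(OC)cc4)sc3n2)c1` differs from compound 2 in one place: 4-methoxyphenyl in place of phenethyl on an aromatic carbon. Since compound 1 with phenyl and compound 2 with phenethyl sit within the scatter of each other, no step beyond the scatter is expected from compound 2 to compound 4; the expected step is a 1.1-fold lower number from compound 2 to compound 4 (0.04 log units; within the scatter). Compound 4 is therefore estimated at 3000 nM in this assay, with a range from 1200 nM to 8000 nM.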

Compound 4, half-maximal inhibitory concentration: 2300 nM
Compound 4: middle estimate off by 1.3-fold (0.12 log units), on the high side; low and high end bracket the measured number.
By their numbers in this assay, from the lowest: compounds 4, 2 and 1 (each within the scatter of the next). At a limit, above all of these: compound 3.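

Among these compounds, at this aromatic carbon, 4-methoxyphenyl in place of phenethyl gives a 1.4-fold lower number from compound 2 to compound 4 (0.16 log units; within the scatter) in this assay, the first step that changes one place only. On this shared core, the two groups are therefore not told apart, although 4-methoxyphenyl brings a hydrogen-bond acceptor that phenethyl lacks. No measured property at hand bears on this step.

From the compounds shown here alone, whether an amine or a carboxylic acid on the aryl ring, or a chain longer than phenethyl, would move the number beyond the scatter remains open.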